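Swapping an amide-bearing benzene for a pyridine in a chemokine antagonist

The source may report more compounds than this note shows. Statements on the series, on what has been measured and on what is new or still open speak of the compounds shown alone.

Of the compounds shown here, three sharing one core have been measured in a functional assay on CEM-CCRF cells for antagonist activity at C-X-C chemokine receptor type 4 (Homo sapiens), read by calcium flux; a lower number here means a stronger inhibitor, a higher number a weaker inhibitor. Compound 1 `NCc1ccc(CN(Cc2nc3ccccc3[nH]2)C2CCCc3cccnc32)c(CN)c1` gives 10 nM. Compound 2 `NCc1cc(C(=O)O)ccc1CN(Cc1nc2ccccc2[nH]1)C1CCCc2cccnc21` gives 126 nM. Compound 3 `NCc1cc(C(N)=O)ccc1CN(Cc1nc2ccccc2[nH]1)C1CCCc2cccnc21` gives 15 nM. On these numbers compound 3 stands second highest of the three: its nearest neighbour is compound 1, a step that is within the scatter, and its furthest is compound 2, a step that is beyond it. The step of a 13-fold higher number from compound 1 to compound 2 (1.10 log units; beyond the scatter) is large, while a 1.5-fold higher number from compound 1 to compound 3 (0.18 log units; within the scatter) is not, and an 8.4-fold lower number from compound 2 to compound 3 (0.92 log units; beyond the scatter) is modest.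

Compound 4 `NCc1ccncc1CN(Cc1nc2ccccc2[nH]1)C1CCCc2cccnc21` is the next compound. Relative to compound 3 the change is a group of 8 heavy atoms (6 carbon, 2 nitrogen; one six-membered aromatic ring with 1 hetero atom) in place of a group of 11 heavy atoms (8 carbon, 2 nitrogen, 1 oxygen; one six-membered aromatic ring of carbon only), on a saturated chain carbon bound to an amine nitrogen. The steps measured so far only speak to the carbamoyl, the carboxy and the aminomethyl on the ring of carbon only; none of them tests a ring with a hetero atom, and none removes the carbamoyl outright. The aminomethyl group that compound 1 and compound 3 both carry is kept. Given that the carbamoyl made little difference in a 1.5-fold higher number from compound 1 to compound 3 (0.18 log units; within the scatter), its loss alone should matter little, but the ring swap is untested, so a modest weakening is expected: a 2.0-fold higher number from compound 3 to compound 4 (0.30 log units; within the scatter). The expected value for compound 4 in this assay is 30 nM, with a range from 8 nM to 120 nM.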

Compound 4, half-maximal inhibitory concentration: 160 nM
Compound 4: middle estimate off by 5.3-fold (0.73 log units), on the low side; the measured number lies above the stated range.
By their numbers in this assay, from the lowest: compounds 1 and 3 (each within the scatter of the next); then compounds 2 and 4 (each within the scatter of the next).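

On a saturated chain carbon bound to an amine nitrogen, replacing the six-membered aromatic ring of carbon only with one holding 1 hetero atom gives an 11-fold higher number from compound 3 to compound 4 (1.03 log units; beyond the scatter) and is a large step, whereas exchanging aminomethyl for carbamoyl on the carbon-only ring stayed within the scatter. The comparison with the compound carrying two aminomethyl groups gives a 16-fold higher number from compound 1 to compound 4 (1.20 log units; beyond the scatter) and is also large, so keeping one aminomethyl group is not enough to hold the number near those of compounds 1 and 3. Measured against the carboxy compound, the same kind of exchange gives a 1.3-fold higher number from compound 2 to compound 4 (0.10 log units; within the scatter) and stays within the scatter, so this group change and the carboxy group leave the inhibitor in the same range, well short of compounds 1 and 3.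

Because the ring atom and the ring substituent change together in compound 4, the shown compounds cannot separate the two effects, and a carbon-only ring carrying a hydroxymethyl group or a methyl group in place of the carbamoyl would bear on that question. No measurement offered here explains the weaker result.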